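Swapping sec-butyl for butyl on a sulfur

The compounds below may be only part of what the source reports. "The series", "measured", "known", "first", "only" and "open" are said of these compounds alone.

Four close relatives share a core in which a sulfur carries a short chain. Compound 1 `CCC(C)Sc1nc(Cc2c(F)cccc2Cl)c(C)c(=O)[nH]1` carries a sec-butyl group on that sulfur. In an ADME assay on MT4 cells (Homo sapiens) for activation, read by MTT assay (on this read-out higher numbers stand for lower toxicity in this test and lower numbers for higher toxicity in this test), compound 1 gives > 73000 nM, which is a limit of the assay and not a number. Compound 2 `CCCCSc1nc(Cc2c(F)cccc2Cl)c(C)c(=O)[nH]1` differs from compound 1 by butyl in place of sec-butyl on a sulfur. In this assay compound 2 gives > 73000 nM, again a limit rather than a number. Going by the values given here, because both values are limits, the step that the two limits leave unreadable from compound 1 to compound 2 cannot be read; the two values show only that both compounds sit at the same limit, as stated in the limit of > 73000 nM in this assay, at which 2 of the 3 values shown sit.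

Compound 3 `CCC(C)Sc1nc(C(CC)c2c(F)cccc2F)c(C)c(=O)[nH]1` has a different core; the difference between its core and the core of compound 1 is not broken down here. In this assay compound 3 gives > 3000 nM, which is a limit of the assay and not a number, as noted in the limit of > 3000 nM in this assay, at which 1 of the 3 values shown sits.

Compound 4 `CCCCSc1nc(C(CC)c2c(F)cccc2F)c(C)c(=O)[nH]1` is not yet measured. It differs from compound 3 by butyl in place of sec-butyl on a sulfur, the same change as from compound 1 to compound 2, at the same place. For compound 4 the expected step is a step that the limit leaves unreadable from compound 3 to compound 4, close to no change, because the measured pair gave a step that the two limits leave unreadable from compound 1 to compound 2 and compound 3 itself gave > 3000 nM. For compound 4 the estimated value in this assay is 40000 nM, expected to lie between 8000 nM and 120000 nM, most likely reported again as a limit.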

Compound 4, half-maximal cytotoxic concentration: > 3000 nM
Compound 4 gave a limit, no number; the forecaster's own chance of this, stated with the estimate: 85%; the middle value is on the limit's open side.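

In this assay compound 4 gives > 3000 nM, which is a limit and not a number. Compound 3 gives > 3000 nM, also a limit. Going by these compounds alone, no step can therefore be read from compound 3 to compound 4, so the swap of sec-butyl for butyl has no readable size here. The compounds shown leave open how toxic each one is to these cells, and whether this swap changes that toxicity at all.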